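Fluoro to trifluoromethyl: estimating a cytotoxicity value

This account rests on a few compounds, and the source may have more. Where it says the series, first, only, none or still open, it means among the compounds named here.

Compound 1 `CC(=O)Nc1ccc2oc(-c3cccc(C(F)(F)F)c3)cc(=O)c2c1`: 10000 nM
Compound 2 `COc1cccc(-c2oc3ccc(NC(C)=O)cc3c(=O)c2OC)c1`: 369000 nM
Compound 3 `COc1c(-c2cccc(F)c2)oc2ccc(NC(C)=O)cc2c1=O`: 210000 nM

All three were tested in an ADME assay on MT4 cells (Homo sapiens) for cytotoxicity, read by MTT assay, with a stated time of 4 days; on this read-out lower numbers stand for higher toxicity in this test and higher numbers for lower toxicity in this test. Compound 3, at 210000 nM, stands level with compound 2 within the scatter, and its number lies well clear of compound 1 at 10000 nM.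

The next compound, compound 4 `COc1c(-c2cccc(C(F)(F)F)c2)oc2ccc(NC(C)=O)cc2c1=O`, matches compound 3 except for one group: trifluoromethyl in place of fluoro on an aromatic carbon. Among the compounds with values here, one measured step touches the same aromatic carbon: a 1.8-fold lower number from compound 2 to compound 3 (0.24 log units; within the scatter). That swap stayed within the scatter, so a change at this carbon need not move the number much. A second clue is a compound that also carries trifluoromethyl but lacks the methoxy of compound 4: compound 1 gives 10000 nM. Three compounds are thin evidence, but together they point to a modest downward move. The expected change is a 2.1-fold lower number from compound 3 to compound 4 (0.32 log units; beyond the scatter). For compound 4 the estimated value is 100000 nM, with an expected range of 30000 nM to 300000 nM.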

Compound 4, half-maximal cytotoxic concentration: 201000 nM
Beside the measured number, compound 4's estimate is 2.0-fold (0.30 log units) below it; the measured number falls inside the stated range.
By their numbers in this assay, from the lowest: compound 1; then compounds 4, 3 and 2 (each within the scatter of the next).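

In this assay trifluoromethyl in place of fluoro on this aromatic carbon gives a 1.0-fold lower number from compound 3 to compound 4 (0.02 log units; within the scatter) and trifluoromethyl in place of methoxy gives a 1.8-fold lower number from compound 2 to compound 4 (0.26 log units; within the scatter) so fluoro, methoxy and trifluoromethyl all stand level here. Within the data shown here, the one large step lies at a different place on the core: with trifluoromethyl kept, methoxy in place of hydrogen gives a 20-fold higher number from compound 1 to compound 4 (1.30 log units; beyond the scatter) and this sets compound 1 apart from compound 4. No measurement shown here explains either result.

As far as these compounds go, whether this aromatic carbon stays as tolerant with an amine, a carboxylic acid or a longer chain remains open. From the compounds shown here alone, it is also open whether the large step seen with methoxy in place of hydrogen would recur with fluoro on the aromatic ring, as only the trifluoromethyl pair shows it.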